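A few compounds are considered here, and "the series" means these few. Any claim that something is new, unique, unknown or untested is made for them only; others in the source may bear on it.

Measured compounds:
compound 1 `O=C([C@@H]1C[C@H]1F)N1CC2CC(C1)N2` gives 110% in an assay on SH-EP1 cells for agonist activity at Neuronal acetylcholine receptor; alpha4/beta2 (Homo sapiens), read by FLIPR and calcium flux; a higher number here means a larger maximal response, a lower number a smaller maximal response
compound 2 `C[C@@H]1C[C@@H]1C(=O)N1CC2CC(C1)N2` gives 88% in this assay

Going by the values given here, compound 2 stands lowest of the two numbers; the only step, a number 22 percentage points lower from compound 1 to compound 2 (beyond the scatter), swaps a fluorine-bearing ring for a methyl-bearing one on the carbonyl carbon. Compound 3 `C[C@H]1C[C@H]1C(=O)N1CC2CC(C1)N2` differs from compound 2 only in configuration: the two compounds have the same atoms and bonds; at least one stereo element is drawn with a configuration in one of them and without one in the other: 2 of 4 stereo elements differ; a stereocentre at a saturated ring carbon is drawn R in compound 2 and S in compound 3; a stereocentre at a saturated ring carbon is drawn S in compound 2 and R in compound 3. No measured step concerns a change of configuration alone, so nothing shown bears directly on it; the swap from compound 1 to compound 2 is not comparable. An unmeasured change of this kind could leave the response unchanged or lower it. Compound 3 is expected at 80%, range 50% to 105%, an estimated step of a number 8 percentage points lower from compound 2 to compound 3 (within the scatter).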

Compound 3, largest response reached (Emax), in percent of the reference or control that the assay uses: 87%
For compound 3 the middle estimate is 7 percentage points below the measured one; the range from low to high includes it.
By their numbers in this assay, from the lowest: compounds 3 and 2 (each within the scatter of the next); then compound 1.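

In this assay, swapping the configuration of the 2-methylcyclopropyl group gives a number 1 percentage points lower from compound 2 to compound 3 (within the scatter), so this change does not separate the two drawn forms. The difference between 2-fluorocyclopropyl and 2-methylcyclopropyl on the carbonyl carbon holds for the second methyl form too, with a number 23 percentage points lower from compound 1 to compound 3 (beyond the scatter). The reading of configuration carries one caution: the fact that one of compounds 2 and 3 is drawn with a defined configuration and the other without, at the place where they differ

On these data alone, it remains open whether the other configuration of 2-fluorocyclopropyl would match compound 1. As far as these compounds go, the response with unsubstituted cyclopropyl, 2-chlorocyclopropyl or an open isobutyl chain on the carbonyl carbon also remains open.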